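The source may report more compounds than this note shows. Statements on the series, on what has been measured and on what is new or still open speak of the compounds shown alone.

Values in a functional assay on MIA PaCa-2 cells (Homo sapiens) for inhibition, read by MTT assay, with a stated time of 72 h; a higher number here means a weaker inhibitor, a lower number a stronger inhibitor:
Compound 1 `COc1cc(NC(C)CCCNC(=O)NNC(=O)Nc2ccc(F)cc2)c2ncccc2c1`: >= 250000 nM, a limit.
Compound 2 `COc1cc(NC(C)CCCNC(=O)NNC(=O)Nc2ccc(C(F)(F)F)cc2)c2ncccc2c1`: 19000 nM.
Compound 3 `COc1cc(NC(C)CCCNC(=O)Nc2cc(C(F)(F)F)cc(C(F)(F)F)c2)c2ncccc2c1`: 4700 nM.

Compound 1 has no number on this read-out, only a limit: the limit of >= 250000 nM in this assay, at which 1 of the 3 values shown sits.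

Next in line is compound 4 `COc1cc(NC(C)CCCNC(=O)Nc2ccc(C(F)(F)F)cc2)c2ncccc2c1`, not yet measured. The change is 4-(trifluoromethyl)phenyl in place of ((4-fluorophenyl)carbamoyl)amino on an amide-type nitrogen.

Among the measured compounds shown here, one measured step bears on this directly: an at least 13-fold lower number from compound 1 to compound 2 (1.11 log units; beyond the scatter), where trifluoromethyl replaces fluoro on an aromatic carbon. Compound 4 also carries trifluoromethyl in place of that fluoro, but it loses the carbamoyl link as well, so that step is only a partial guide. Compound 3, at 4700 nM, resembles compound 4 in having its aromatic ring directly on the amide-type nitrogen.

On these grounds, a large step to a lower number is expected: an at least 27-fold lower number from compound 1 to compound 4 (1.44 log units; beyond the scatter). Compound 4 is estimated at 9000 nM, with an expected range of 3000 nM to 30000 nM.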

Compound 4, half-maximal inhibitory concentration: 8400 nM
The estimate for compound 4 lay 1.1-fold (0.03 log units) above the measured number, within the range that was stated.
By their numbers in this assay, from the lowest: compounds 3 and 4 (each within the scatter of the next); then compound 2. At a limit, above all of these: compound 1.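

In this assay, 4-(trifluoromethyl)phenyl in place of ((4-fluorophenyl)carbamoyl)amino on the amide-type nitrogen gives an at least 29-fold lower number from compound 1 to compound 4 (1.47 log units; beyond the scatter). This shows that the carbamoyl link can go from this position and the series still gives a number on this read-out. The size of that step is only a bound, since compound 1 stands at a limit: the limit of >= 250000 nM in this assay, at which 1 of the 4 values shown sits.

The step carries the loss of the carbamoyl link and the change from fluoro to trifluoromethyl together, so the data do not divide it between the two; 4-fluorophenyl on the same nitrogen would separate them. Also open, as far as these compounds go, is how an amine or a carboxylic acid on the aromatic ring, or a longer chain in place of the present one, would read in this assay.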